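Imidazole anilides: shortening the sulfanyl heteroaryl group

This account rests on a few compounds, and the source may have more. Where it says the series, first, only, none or still open, it means among the compounds named here.

Measured so far in a functional assay on MCF7 cells (Homo sapiens) for cytotoxicity, read by MTT assay, with a stated time of 24 h, tested at 16 ug/mL; a higher number here means a stronger effect of the compound at the concentration tested, a lower number a weaker effect:
Compound 1, `Cn1c(-c2ccc(NC(=O)CSc3nc4ccccc4o3)cc2)nc(-c2ccccc2)c1-c1ccccc1`, gives 56%.
Compound 2, `Cn1c(-c2ccc(NC(=O)CSc3nc4ccccc4s3)cc2)nc(-c2ccccc2)c1-c1ccccc1`, gives 50.3%.

Within the data shown here, compound 2 stands at the lower of the two numbers, but its only neighbour is compound 1, and the step of a number 5.7 percentage points lower from compound 1 to compound 2 (within the scatter) is within the scatter, so the two compounds cannot be ranked against each other in this assay.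

Compound 3, `Cn1ccnc1SCC(=O)Nc1ccc(-c2nc(-c3ccccc3)c(-c3ccccc3)n2C)cc1`, is not yet measured. It differs from compound 2 as follows: 1-methyl-1H-imidazol-2-yl in place of 1,3-benzothiazol-2-yl on a sulfur. Among the measured compounds shown here, the only measured step, a number 5.7 percentage points lower from compound 1 to compound 2 (within the scatter), exchanges one bicyclic heteroaryl for another on the same sulfur and does not bear on losing the six-membered carbon ring; it shows only that the two bicyclic groups behave alike. For the measured compounds named here, no measured step covers the change to a single five-membered ring, so the expectation rests on the smaller size of the entering group alone, with wide uncertainty.

Compound 3 is therefore estimated at 40%, in the range 20% to 58%, a step of a number 10.3 percentage points lower from compound 2 to compound 3 (beyond the scatter) that is expected to lean downward but could fall within the scatter.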

Compound 3, a percentage reported as activity, at one concentration (the size of the read-out at that concentration, not a potency): 32.4%
Beside the measured number, compound 3's estimate is 7.6 percentage points above it; low and high end bracket the measured number.
By their numbers in this assay, from the lowest: compound 3; then compounds 2 and 1 (each within the scatter of the next).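

In this assay the group on the sulfur proves able to move the read-out: the step is a number 17.9 percentage points lower from compound 2 to compound 3 (beyond the scatter), and with the other bicyclic group leaving it is a number 23.6 percentage points lower from compound 1 to compound 3 (beyond the scatter), whereas the exchange of the two bicyclic groups alone stayed within the scatter. With 1-methyl-1H-imidazol-2-yl entering, the six-membered aromatic ring of carbon only is lost, while the methyl and the change in hetero atoms arrive in the same step, so these compounds cannot assign the lower number to any one of these differences. Nothing measured here speaks to the reason for the lower number.

Open, from the compounds shown here alone, is whether 1H-imidazol-2-yl without the methyl would stand with compound 3, and whether 1H-benzimidazol-2-yl, which keeps the six-membered aromatic ring of carbon only, would stand with compounds 1 and 2. Also open, going by these compounds, is whether a plain phenyl on the sulfur would hold the number, and whether the gap would persist at other concentrations, as a read-out at a single concentration gives no potency.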